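Half-life of compound 4 after a ring exchange

The compounds below may be only part of what the source reports. "The series", "measured", "known", "first", "only" and "open" are said of these compounds alone.

Measured in an ADME assay on microsomes from liver (Mus musculus) for metabolic stability, read by LC-MS, using NADPH, with stated times of 15 min and 60 min, tested at 4.6 uM; on this read-out higher numbers stand for a longer-lived compound and lower numbers for a shorter-lived compound:
compound 1 `CN1CCN(c2ccc3c(c2)oc(=O)n3C(=O)NCCCCc2ccccc2)CC1` gives < 0.0834 h
compound 2 `CC(C)CNC(=O)n1c(=O)oc2cc(C3CCCCN3C)ccc21` gives 0.25 h
compound 3 `CC(C)CNC(=O)n1c(=O)oc2cc(C3CCCN(C)C3)ccc21` gives > 1 h

The result for compound 1 is < 0.0834 h, which is a limit and not a number. The result for compound 3 is > 1 h, which is also a limit. Compound 4 `CCN1CCC(c2ccc3c(c2)oc(=O)n3C(=O)NCCCCc2ccccc2)CC1` differs from compound 1 in one place, where 1-ethylpiperidin-4-yl replaces 4-methylpiperazin-1-yl on an aromatic carbon: 1-ethylpiperidin-4-yl in place of 4-methylpiperazin-1-yl on an aromatic carbon.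

For the measured compounds named here, only one measured step bears on this change, and only loosely. It is an at least 4.0-fold higher number from compound 2 to compound 3 (0.60 log units; beyond the scatter), which shows that an exchange in this same place can move the half-life. That step swaps one 1-methylpiperidine attachment for another, however, and compounds 2 and 3 also differ from compound 1 elsewhere. A small rise is therefore expected in this assay, and no change beyond the scatter is equally plausible. The expected size is an at least 1.1-fold higher number from compound 1 to compound 4 (0.07 log units; that floor lies within the scatter). For compound 4 the estimated half-life is 0.1 h, with an expected range from 0.05 h to 0.25 h.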

Compound 4, half-life: 1 h
Compound 4: the middle estimate sits 10-fold (1.00 log units) below what was measured, and the stated range ends below it.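

In this assay, replacing the ring on this aromatic carbon gives an at least 11-fold higher number from compound 1 to compound 4 (1.07 log units; beyond the scatter), so this position responds strongly to a change of the ring itself and not only to where a ring is attached, which was all that the earlier step from compound 2 to compound 3 had varied. Going by these compounds, the value of compound 1, < 0.0834 h, is a limit of the assay, so the size of this step is a floor and its true size stays unknown. For the compounds shown here, the step also shows that a large rise in half-life is possible on the phenylbutyl urea side of the series, whereas the earlier step was seen only with the isobutyl group.

The exchange changes the ring hetero atoms and the alkyl group on nitrogen together, so the compounds shown do not separate these two changes. A 1-methylpiperidin-4-yl or a 4-ethylpiperazin-1-yl group in this place would tell them apart.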